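A pyrazine in place of the fluorophenyl on the shared core

A few compounds are considered here, and "the series" means these few. Any claim that something is new, unique, unknown or untested is made for them only; others in the source may bear on it.

The series is judged in an assay on isolated protein for inhibition of acid ceramidase (Homo sapiens), read by LC-MS, with a stated time of 1 h; on this read-out lower numbers stand for stronger inhibition and higher numbers for weaker inhibition. Compound 1 `CCCCCNC(=O)n1c(-c2ccccc2)coc1=O` gives 25 nM in this assay. Compound 2 `O=c1[nH]cc(-c2ccccc2)o1`, which lacks the carbamate side chain, is reported in this assay as "not active" (no number reported). Compound 3 `O=C(NCCCCc1ccccc1)n1cc(-c2ccc(F)cc2)oc1=O` gives 185 nM in this assay; of the two compounds with a reported number it stands at the higher one, with compound 1 some way below it, and that gap lies beyond the usual scatter.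

Compound 4 `O=C(NCCCCc1ccccc1)n1cc(-c2cnccn2)oc1=O` is the next member: it keeps the phenylbutyl carbamate chain of compound 3 and differs from it only in the aryl group, with pyrazin-2-yl in place of 4-fluorophenyl on an aromatic carbon. Within the data shown here, no pair of measured compounds in this set differs in exactly this way, so there is no directly comparable step to lean on. Among the measured compounds shown here, the only comparison available, compound 1 against compound 3, changes two things at once and says nothing about the aryl group on its own.

For compound 4 the author expects a moderate rise in the number, an estimated step of a 2.2-fold higher number from compound 3 to compound 4 (0.33 log units; beyond the scatter), that may or may not clear the scatter. Compound 4 is therefore estimated at 400 nM in this assay, with a plausible range from 100 nM to 1500 nM.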

Compound 4, half-maximal inhibitory concentration: 32 nM
For compound 4 the middle estimate is 13-fold (1.10 log units) above the measured one, and the stated range ends above it.
By their numbers in this assay, from the lowest: compounds 1 and 4 (each within the scatter of the next); then compound 3.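

Among these compounds, compound 4 gives the first reading of the aryl group on its own: with the phenylbutyl carbamate chain held fixed in this assay, placing pyrazin-2-yl instead of 4-fluorophenyl on the aromatic carbon next to the ring oxygen gives a 5.8-fold lower number from compound 3 to compound 4 (0.76 log units; beyond the scatter), a modest step that lies beyond the scatter. This position therefore accepts a six-membered aromatic ring with 2 hetero atoms and 2 hydrogen-bond acceptors in place of a ring of carbon only, and the number does not rise with this change. Nothing measured in this set explains the drop, so the step stands as an observation without a known cause.

A single step cannot separate the loss of the fluorine from the entry of the two ring nitrogens, and a plain phenyl or a pyridin-2-yl group on the same phenylbutyl carbamate would be needed to tell these apart. It also remains open whether the step would carry over to a shorter chain such as pentyl, since the compounds shown offer no second pair with this change.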